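This account rests on a few compounds, and the source may have more. Where it says the series, first, only, none or still open, it means among the compounds named here.

In an ADME assay on HT-29 cells (Homo sapiens) for cytotoxicity, read by luminescence and CellTiter-Glo, with a stated time of 10 h (a higher number here means that more compound is tolerated, a lower number that less compound is tolerated), compound 1 `Cc1ccc2c(n1)OC[C@H](NC(=O)c1n[nH]c(Cc3ccccc3)n1)C(=O)N2C` gives > 50000 nM, which is a limit of the assay and not a number. Compound 2 `CN1C(=S)[C@@H](NC(=O)c2n[nH]c(Cc3ccccc3)n2)COc2cccnc21` gives > 50000 nM, which is also a limit and not a number. Compound 2 therefore stands at the limit of > 50000 nM in this assay, at which 2 of the 2 values shown sit, so no exact cytotoxic concentration is known for either compound.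

The next compound to be tested, compound 3 `CN1C(=S)[C@H](NC(=O)c2n[nH]c(Cc3ccccc3)n2)COc2cccnc21`, changes only how one centre is drawn: the two compounds have the same atoms and bonds and differ only in configuration as drawn: 1 of 1 stereo elements differ; a stereocentre at a saturated ring carbon is drawn S in compound 2 and R in compound 3. Its atoms and bonds are the same as those of compound 2, and only the stereocentre at a saturated ring carbon differs. Among the measured compounds shown here, no measured pair in this small set shows what such a change does here. The expectation rests on compound 2, with its limit of > 50000 nM. In this assay, no step beyond the usual scatter is expected, and the estimated step is a number no higher from compound 2 to compound 3 (the limit leaves the size open). The expected value for compound 3 is 50000 nM, with an estimated range from 20000 nM to 50000 nM.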

Compound 3, half-maximal cytotoxic concentration: > 50000 nM
Compound 3 gave a limit, no number; the forecaster's own chance of this, stated with the estimate: 85%; the middle value sits exactly at the limit.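

Among the compounds shown here, compound 2 and compound 3 both give a limit of the assay and not a number, so no step between them can be read. Still open is whether the two configurations differ at all, and at what concentration any of the three compounds harms these cells: the limit of > 50000 nM in this assay, at which 3 of the 3 values shown sit.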